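The compounds below may be only part of what the source reports. "The series", "measured", "known", "first", "only" and "open" are said of these compounds alone.

Compound 1 `NCc1csc(NC(=O)c2ncccn2)n1`: > 100 ug/mL (a limit)
Compound 2 `CC(C)(C)c1cc(C(=O)Nc2ccccn2)n(Cc2ccccc2)n1`: 25 ug/mL
Compound 3 `CC(C)(C)c1cc(C(=O)Nc2ccccc2)n(Cc2ccccc2)n1`: 1.6 ug/mL

These values come from a physicochemical assay for solubility, read by nephelometry, measured as kinetic solubility, at pH 2.0; on this read-out higher numbers stand for higher solubility and lower numbers for lower solubility. The value of compound 1 is a limit and not a number. Of the two true numbers, compound 3 holds the lower at 1.6 ug/mL, and compound 2 stands above it, beyond the scatter.

Compound 4 `CC(C)(C)c1cc(C(=O)Nc2nc(CO)cs2)n(Cc2ccccc2)n1` carries 4-(hydroxymethyl)-1,3-thiazol-2-yl in place of phenyl on an amide-type nitrogen. For the measured compounds named here, one measured step bears on this change, and it is large and beyond the scatter: a 16-fold lower number from compound 2 to compound 3 (1.19 log units; beyond the scatter). There, phenyl takes the place of pyridin-2-yl at the same amide-type nitrogen. On the strength of a 16-fold lower number from compound 2 to compound 3 (1.19 log units; beyond the scatter), read in reverse, a rise of similar size in this assay is expected, beyond the scatter. The entering group is not pyridin-2-yl, however, so the size rests on this single comparison and remains uncertain. The expected change is a 13-fold higher number from compound 3 to compound 4 (1.10 log units; beyond the scatter). Compound 4 is estimated at 20 ug/mL, with an expected range from 5 ug/mL to 80 ug/mL.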

Compound 4, solubility: 12.5 ug/mL
Estimate against measurement, compound 4: 1.6-fold (0.20 log units) above; the measured number falls inside the stated range.
By their numbers in this assay, from the lowest: compound 3; then compounds 4 and 2 (each within the scatter of the next). At a limit, above all of these: compound 1.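

Replacing phenyl with 4-(hydroxymethyl)-1,3-thiazol-2-yl at the amide-type nitrogen gives a 7.8-fold higher number from compound 3 to compound 4 (0.89 log units; beyond the scatter). Phenyl therefore now gives the lowest number against two different groups at this nitrogen, where the earlier compounds offered only pyridin-2-yl for comparison. In this assay the two non-phenyl groups cannot be told apart, as the step between them reads a 2.0-fold lower number from compound 2 to compound 4 (0.30 log units; within the scatter), and nothing measured here bears on the cause of these steps.

The compounds shown do not separate the share of the 1,3-thiazol-2-yl ring from that of its hydroxymethyl group, as both enter together in compound 4. They also leave open how a carboxylic acid or an amine in place of the hydroxyl would read at this nitrogen on the shared core.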